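Does a Methyl Restore Potency at a New Ring Position?

The source may hold more compounds than are shown below. What is called first, only, known or untested is meant among the compounds shown, and "the series" means these compounds.

Measured so far:
compound 1 `COC(=O)c1sc2cc(C)ccc2c1Nc1cc(OC)c(OC)c(OC)c1` gives 0.6 nM
compound 2 `COC(=O)c1sc2ccccc2c1Nc1cc(OC)c(OC)c(OC)c1` gives 490 nM

In a functional assay on Jurkat cells (Homo sapiens) for cytotoxicity, read by MTT assay, with a stated time of 72 h (on this read-out lower numbers stand for stronger inhibition and higher numbers for weaker inhibition), compound 2 stands at the highest of the two numbers seen; its nearest neighbour is compound 1, which gives 0.6 nM. For the measured compounds named here, the one step that separates them, an 820-fold higher number from compound 1 to compound 2 (2.91 log units; beyond the scatter), shows that losing the methyl from the fused ring of carbon only costs a great deal of potency.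

Compound 3 `COC(=O)c1sc2ccc(C)cc2c1Nc1cc(OC)c(OC)c(OC)c1` has not yet been measured. It differs from compound 2 by methyl in place of hydrogen on an aromatic carbon, the methyl entering meta to a fused ring and para to a fused ring. Compound 3 is therefore not the same molecule as compound 1, so the large step from compound 1 to compound 2 bears on it only loosely: the methyl helps at one place, but the data say nothing about this place. Some recovery in this assay is expected, yet smaller and far less certain than the known step.

Compound 3 is expected to give 40 nM, in the range 3 nM to 500 nM, which corresponds to an expected step of a 12-fold lower number from compound 2 to compound 3 (1.09 log units; beyond the scatter).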

Compound 3, half-maximal inhibitory concentration: 727 nM
Beside the measured number, compound 3's estimate is 18-fold (1.26 log units) below it; measured number above the stated range.
By their numbers in this assay, from the lowest: compound 1; then compounds 2 and 3 (each within the scatter of the next).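

In this assay, methyl in place of hydrogen at this position, meta to a fused ring and para to a fused ring, gives a 1.5-fold higher number from compound 2 to compound 3 (0.17 log units; within the scatter) and leaves compound 2 and compound 3 indistinguishable. The large step from the methyl of compound 1, an 820-fold higher number from compound 1 to compound 2 (2.91 log units; beyond the scatter) on its removal, therefore holds for that one place and does not extend to every carbon of this six-membered ring: simply having a methyl on the ring is not enough for high potency. Nothing measured here accounts for the difference between the two places.

As far as these compounds go, whether a different group at this position, such as a methoxy, a chlorine or an amine, would separate from hydrogen remains open. Also open, from the compounds shown here alone, is how a methyl would behave on the remaining carbons of the same ring.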